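The source may hold more compounds than are shown below. What is called first, only, known or untested is meant among the compounds shown, and "the series" means these compounds.

In a functional assay on MOLT-4F cells (Homo sapiens) for antiproliferative activity (on this read-out lower numbers stand for stronger inhibition of growth and higher numbers for weaker inhibition of growth), compound 1 `COCCCCCCCCCCCCCCC/C=C1\CC(CO)(COC(=O)C(C)(C)C)OC1=O` gives 0.498 ug/mL and compound 2 `CCCCCCCCC(O)CCCCCC/C=C1\CC(CO)(COC(=O)C(C)(C)C)OC1=O` gives 7.91 ug/mL, the higher of the two numbers and so the weaker growth inhibition. Compound 3 `CC(C)(C)C(=O)OCC1(CO)C/C(=C\CCCCCCCCCCCO)C(=O)O1` has not yet been measured. In it, 5-hydroxypentyl takes the place of 1-hydroxynonyl: 5-hydroxypentyl in place of 1-hydroxynonyl on a saturated chain carbon, six bonds along the chain from a double-bonded chain carbon. For the measured compounds named here, the only measured step, a 16-fold higher number from compound 1 to compound 2 (1.20 log units; beyond the scatter), is large and also alters the chain, but it swaps different groups, so it gives no clear direction for this change. The expected step, a 1.0-fold higher number from compound 2 to compound 3 (0.00 log units; within the scatter), is therefore estimated to stay within the scatter. Compound 3 is estimated at 8 ug/mL, with an expected range of 2.5 ug/mL to 25 ug/mL.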

Compound 3, concentration for 50% growth inhibition: 1.34 ug/mL
Compound 3: middle estimate off by 6.0-fold (0.78 log units), on the high side, and the stated range ends above it.
By their numbers in this assay, from the lowest: compound 1; then compound 3; then compound 2.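

In this assay, 5-hydroxypentyl in place of 1-hydroxynonyl is not a neutral swap: it gives a 5.9-fold lower number from compound 2 to compound 3 (0.77 log units; beyond the scatter) and so shows that this place on the chain responds to the change. Hydroxy in place of 4-methoxybutyl gives a 2.7-fold higher number from compound 1 to compound 3 (0.43 log units; beyond the scatter) and leaves compound 1 with the lowest number of the three. Nothing measured here explains either step. The compounds shown leave open whether an amine or a carboxylic acid at this place on the chain would reach or pass compound 1.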